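A few compounds are considered here, and "the series" means these few. Any claim that something is new, unique, unknown or untested is made for them only; others in the source may bear on it.

Measured so far in a physicochemical assay for solubility; a higher number here means a more soluble compound, a lower number a less soluble compound:
compound 1, `CCCCCCCCCCCCCCCC(=O)n1c(=S)oc2ccccc21`, compound 1 gives 63000 nM
compound 2, `COC(=O)c1ccc2oc(=S)n(C(=O)CCc3ccccc3)c2c1`, compound 2 gives 200000 nM

Compound 1 holds the lower of the two numbers; the gap to compound 2 lies beyond the usual scatter of repeated measurements, so compound 1 reads as the less soluble of the pair on what is known. Compound 2 differs from compound 1 at several places at once, so the two values show only that, and nothing about any single change.

The next compound, compound 3, is `CCCCCCCCCC(=O)n1c(=S)oc2ccccc21`. It differs from compound 1 in one place: hydrogen in place of hexyl on a saturated chain carbon, nine bonds along the chain from a carbonyl carbon.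

Among the measured compounds shown here, no pair of measured compounds differing in one place exists here, so no measured step gives the direction. For the measured compounds named here, the expectation for this assay is a rise beyond the scatter on going from compound 1 to compound 3, but its size rests on no measured step and is uncertain. The expected step from compound 1 to compound 3 is a 6.3-fold higher number from compound 1 to compound 3 (0.80 log units; beyond the scatter). Compound 3 is estimated at 400000 nM, within a range from 100000 nM to 2000000 nM.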

Compound 3, solubility: 100000 nM
Compound 3: the middle estimate sits 4.0-fold (0.60 log units) above what was measured; low and high end bracket the measured number.
By their numbers in this assay, from the lowest: compounds 1, 3 and 2 (each within the scatter of the next, the first and the last beyond it).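

In this assay, among the compounds shown here, the exchange of hexyl for hydrogen on a saturated chain carbon, nine bonds along the chain from a carbonyl carbon, gives a 1.6-fold higher number from compound 1 to compound 3 (0.20 log units; within the scatter) and is the only one-place step available. The same difference, read as heptyl to methyl, octyl to ethyl or nonyl to propyl, therefore leaves compound 1 and compound 3 inseparable in this measurement, and the two chain lengths cannot be ranked against each other on these data. Nothing available bears on why this change leaves the reading within the scatter.

A single step at a single place leaves open how a longer chain, or an amine or a carboxylic acid at the far end of the chain, would read on the core of compound 1. Compound 2 still differs from both compound 1 and compound 3 at several places, so its value cannot be tied to any one change, and whether the chain alone can ever move the reading beyond the scatter remains unsettled.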